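The source may hold more compounds than are shown below. What is called first, only, known or untested is meant among the compounds shown, and "the series" means these compounds.

In a functional assay on B16 cells (Mus musculus) for antiproliferative activity, read by MTT assay, with a stated time of 24 h (on this read-out lower numbers stand for stronger inhibition and higher numbers for weaker inhibition), compound 1 `C=CCOc1ccc2c(=O)c(-c3cc(OC)c(OC)cc3OC)coc2c1` gives 5100 nM and compound 2 `COc1cc(OC)c(-c2coc3cc(OCc4cccc(F)c4)ccc3c2=O)cc1OC` gives 2440 nM, the lower of the two numbers. Compound 3 `COc1cc(OC)c(-c2coc3cc(OCc4cccc(Cl)c4)ccc3c2=O)cc1OC` differs from compound 2 in one place: chloro in place of fluoro on an aromatic carbon, with chloro in place of fluoro on an aromatic carbon. For the measured compounds named here, the only measured step, a 2.1-fold lower number from compound 1 to compound 2 (0.32 log units; beyond the scatter), put 3-fluorophenyl in place of vinyl and was modest. Going by the values given here, that swap was larger than this one, and no measured step covers fluoro against chloro, so no step beyond the scatter is expected here. The expected change is a 1.1-fold lower number from compound 2 to compound 3 (0.04 log units; within the scatter). For compound 3 the estimated value is 2200 nM, within an expected range of 1100 nM to 4500 nM.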

Compound 3, half-maximal inhibitory concentration: 2280 nM
Compound 3: the middle estimate sits 1.0-fold (0.02 log units) below what was measured; measured number inside the range.
By their numbers in this assay, from the lowest: compounds 3 and 2 (each within the scatter of the next); then compound 1.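

In this assay, chloro in place of fluoro on this aromatic carbon gives a 1.1-fold lower number from compound 2 to compound 3 (0.03 log units; within the scatter), so this assay does not separate these two halogens at this place. With chloro, the 3-chlorophenyl in place of vinyl gives a 2.2-fold lower number from compound 1 to compound 3 (0.35 log units; beyond the scatter), so the modest step seen with the fluoro group also holds with chloro. Nothing available explains these results.

From the compounds shown here alone, it remains open whether a methoxy group, a nitrile or an amine at this same place would separate from fluoro and chloro. Also open, going by these compounds, is what a longer chain in place of the 3-chlorobenzyl group would do.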